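The compounds below may be only part of what the source reports. "The series", "measured", "known", "first", "only" and "open" are said of these compounds alone.

Compound 1 `CC(C)c1ccccc1OS(=O)(=O)c1cccc(NC(=O)CCl)c1` is measured in a functional assay on M21 cells (Homo sapiens) for antiproliferative activity, read by sulforhodamine B assay, with a stated time of 48 h (on this read-out higher numbers stand for weaker inhibition and lower numbers for stronger inhibition), where compound 1 gives 3900 nM. Compound 2 `CCC(=O)Nc1ccc(S(=O)(=O)Oc2ccccc2C(C)C)cc1` gives 11000 nM in this assay, and compound 3 `CCC(=O)Nc1ccc(S(=O)(=O)Oc2ccccc2I)cc1` gives 11000 nM; the step of no change at the digits printed from compound 2 to compound 3 (within the scatter) shows that exchanging the group on the aromatic ring left the read-out unchanged. Compound 3 therefore stands level with compound 2 at the digits shown, and the two share the highest numbers of the three; only compound 1 gives a lower number, and that gap lies beyond the scatter.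

Compound 4 `CCCNC(=O)Nc1ccc(S(=O)(=O)Oc2ccccc2I)cc1` differs from compound 3 only at the carbonyl carbon: propylamino in place of ethyl on a carbonyl carbon. Within the data shown here, no measured step touches this part of the molecule; the single measured step, no change at the digits printed from compound 2 to compound 3 (within the scatter), concerns the aromatic ring and was flat. With nothing that speaks for a shift in either direction, compound 4 is expected to stay close to compound 3, with an estimated step of no change at the digits printed from compound 3 to compound 4 (within the scatter). The estimate for compound 4 in this assay is 11000 nM, ranging from 4000 nM to 30000 nM.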

Compound 4, half-maximal inhibitory concentration: 5400 nM
The estimate for compound 4 lay 2.0-fold (0.31 log units) above the measured number; low and high end bracket the measured number.
By their numbers in this assay, from the lowest: compounds 1 and 4 (each within the scatter of the next); then compounds 2 and 3 (each within the scatter of the next).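

Exchanging ethyl for propylamino on the carbonyl carbon turns propanoylamino into (propylcarbamoyl)amino and gives a 2.0-fold lower number from compound 3 to compound 4 (0.31 log units; beyond the scatter) in this assay. Among these compounds, this shows that the read-out responds to a change at this carbonyl carbon, whereas the one earlier step, no change at the digits printed from compound 2 to compound 3 (within the scatter), came from a change on the aromatic ring and stayed within the scatter. Nothing available says whether the added nitrogen with its hydrogen-bond donor or the longer carbon chain accounts for the step.

Going by these compounds, it remains open whether a shorter methylamino group, a longer butylamino chain or a ring such as piperidine on this carbonyl carbon would lower the number further or raise it. The compounds shown also leave open whether propylamino would give a similar step with isopropyl in place of iodo on the aromatic ring.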